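The source may report more compounds than this note shows. Statements on the series, on what has been measured and on what is new or still open speak of the compounds shown alone.

Working notes on the series.

Compound 1 `CNC(=O)[C@@]12C[C@@H]1[C@@H](n1cnc3c(NC)nc(C#Cc4cccnc4)nc31)[C@H](O)[C@@H]2O` and compound 2 `CNC(=O)[C@@]12C[C@@H]1[C@@H](n1cnc3c(NC)nc(C#Cc4nccs4)nc31)[C@H](O)[C@@H]2O` share one core and differ only on a triple-bonded carbon. In an assay on CHO cells for displacement of a labelled ligand from adenosine receptor A1 (Homo sapiens), read by scintillation counting, with a stated time of 60 min, tested at 10 uM (a lower number here means less inhibition, a higher number more inhibition at the concentration tested (going by the name of the read-out)), compound 1 gives 16% and compound 2 gives 31%; the step of a number 15 percentage points higher from compound 1 to compound 2 (beyond the scatter) is recorded as beyond the scatter. Among the two numbers so far, compound 2 stands highest, with compound 1 as its nearest neighbour.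

Compound 3 `CNC(=O)[C@@]12C[C@@H]1[C@@H](n1cnc3c(NC)nc(C#CC4CC4)nc31)[C@H](O)[C@@H]2O` is not yet measured. Its difference from compound 2 is cyclopropyl in place of 1,3-thiazol-2-yl on a triple-bonded carbon. Going by the values given here, the one measured step, from pyridin-3-yl to 1,3-thiazol-2-yl, exchanges one aromatic ring for another and so bears only loosely on an exchange for cyclopropyl; it shows that this position can shift the read-out by a modest amount. For compound 3 the expected step is a number 7 percentage points lower from compound 2 to compound 3 (within the scatter), a small decrease that may fall within the scatter. The estimate for compound 3 in this assay is 24%, within 5% to 48%.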

Compound 3, a percentage reported as inhibition, at one concentration (the size of the read-out at that concentration, not a potency): 38%
Estimate against measurement, compound 3: 14 percentage points below; low and high end bracket the measured number.
By their numbers in this assay, from the lowest: compound 1; then compounds 2 and 3 (each within the scatter of the next).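

In this assay the step of a number 7 percentage points higher from compound 2 to compound 3 (within the scatter) shows that cyclopropyl, a three-membered non-aromatic ring of carbon only, cannot be told apart from the five-membered aromatic 1,3-thiazol-2-yl at this position, so an aromatic ring on the triple-bonded carbon is not needed to keep the read-out at this level. The step of a number 22 percentage points higher from compound 1 to compound 3 (beyond the scatter) adds that compound 1 stands apart from cyclopropyl as well as from 1,3-thiazol-2-yl, which leaves pyridin-3-yl as the group with the lowest number of the three. No evidence on the reason for these steps is at hand.

Open, on these data alone, is how a longer open carbon chain, or a chain ending in an amine or a carboxylic acid, would read on the triple-bonded carbon. These single-concentration numbers also leave the potency of all three compounds open.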